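The compounds below may be only part of what the source reports. "The series", "measured", "known", "first", "only" and "open" are said of these compounds alone.

Working notes on the series. Of the compounds shown here, two have so far been measured in a functional assay on MIA PaCa-2 cells (Homo sapiens) for inhibition, read by MTT assay, with a stated time of 7 days; on this read-out higher numbers stand for weaker inhibition and lower numbers for stronger inhibition. Compound 1 `CCN(CC)S(=O)(=O)c1ccc(S(=O)(=O)N2CCC[C@@H](C(=O)NC3CN(C(=O)OC(C)(C)C)C3)C2)cc1` carries a 1-(tert-butoxycarbonyl)azetidin-3-yl group on the amide-type nitrogen; in this assay compound 1 gives 200 nM, the lowest of the two numbers. Compound 2 `CCOC(=O)[C@@H]1CCCN(S(=O)(=O)c2ccc(S(=N)(=O)N(CC)CC)cc2)C1` differs from compound 1 in more than one place and is not a single step from it; in this assay compound 2 gives 2600 nM, a higher number than compound 1, and the gap between the two lies beyond the usual scatter.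

Compound 3 `CCN(CC)S(=O)(=O)c1ccc(S(=O)(=O)N2CCC[C@@H](C(=O)NC3COC3)C2)cc1` is the next compound for this assay and differs from compound 1 in one place only: oxetan-3-yl in place of 1-(tert-butoxycarbonyl)azetidin-3-yl on an amide-type nitrogen. The group that leaves is the larger one; what enters keeps a four-membered non-aromatic ring with one hetero atom but drops the tert-butoxycarbonyl part. Within the data shown here, no measured pair shows a change of this kind, so the size of the step rests on judgement alone. For compound 3 a moderate move toward a higher number is expected, with a 3.0-fold higher number from compound 1 to compound 3 (0.48 log units; beyond the scatter), the direction uncertain and the step possibly within the scatter. Compound 3 is estimated at 600 nM, with a range of 150 nM to 2500 nM.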

Compound 3, half-maximal inhibitory concentration: 2300 nM
Beside the measured number, compound 3's estimate is 3.8-fold (0.58 log units) below it; measured number inside the range.
By their numbers in this assay, from the lowest: compound 1; then compounds 3 and 2 (each within the scatter of the next).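

Oxetan-3-yl in place of 1-(tert-butoxycarbonyl)azetidin-3-yl on the amide-type nitrogen gives a 12-fold higher number from compound 1 to compound 3 (1.06 log units; beyond the scatter) in this assay, the first single-place step in the series, and it shows that the number responds strongly to the group at this position. A four-membered non-aromatic ring with one hetero atom stands on both sides of the step, so keeping that ring type alone does not keep the number of compound 1, yet the change also goes from 11 heavy atoms to 4, drops the tert-butoxycarbonyl part and replaces the ring nitrogen with oxygen, and one step cannot separate these parts. No measurement at hand offers an explanation for the size of this step.

Still open, on these data alone, is whether the lower number of compound 1 goes with the tert-butoxycarbonyl part or with the azetidine ring itself; the free azetidin-3-yl amine and an N-acetylazetidin-3-yl group on the same nitrogen would help to divide the two. The compounds shown also leave open how an open chain, such as a tert-butyl or n-butyl group, would read at this position.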